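The source may report more compounds than this note shows. Statements on the series, on what has been measured and on what is new or still open speak of the compounds shown alone.

Measured compounds:
Compound 1 `Nc1nc(N)c2c(-c3cc4ccccc4o3)cn([C@@H]3O[C@H](CO)[C@@H](O)[C@H]3O)c2n1` — in a functional assay on HCT-116 cells (Homo sapiens), read by MTT assay, with a stated time of 72 h (on this read-out higher numbers stand for weaker inhibition and lower numbers for stronger inhibition), compound 1 gives > 20000 nM, a limit of the assay.
Compound 2 `CNc1ncnc2c1c(-c1ccsc1)cn2[C@@H]1O[C@H](CO)[C@@H](O)[C@H]1O` — in this assay compound 2 gives > 20000 nM, a limit of the assay.
Compound 3 `Cc1nc(N)c2c(-c3cc4ccccc4o3)cn([C@@H]3O[C@H](CO)[C@@H](O)[C@H]3O)c2n1` — in this assay compound 3 gives > 20000 nM, a limit of the assay.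

Compound 3 stands at the limit of > 20000 nM in this assay, at which 3 of the 3 values shown sit, so no order among the three measured compounds can be read. Within the data shown here, the one single-point step recorded, a step that the two limits leave unreadable from compound 1 to compound 3, is unreadable for the same reason. Compound 4 `Cc1nc(N)c2c(-c3ccco3)cn([C@@H]3O[C@H](CO)[C@@H](O)[C@H]3O)c2n1` differs from compound 3 by furan-2-yl in place of 1-benzofuran-2-yl on an aromatic carbon. Among the measured compounds shown here, no measured step bears on this change. For the measured compounds named here, since compound 3 sits at a limit, no size of step in this assay can be predicted in either direction. Compound 4 is therefore expected to remain at or near the limit, estimated at 30000 nM (range 8000 nM to 100000 nM). The expected step that the limit leaves unreadable from compound 3 to compound 4 is thus taken as nothing readable beyond the scatter.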

Compound 4, half-maximal inhibitory concentration: > 20000 nM
Compound 4: a limit, no number; the forecaster's own chance of this, stated with the estimate: 80%; the middle value is on the limit's open side.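

No step can be read from compound 3 to compound 4, since both values are limits, as is every value in the series: the limit of > 20000 nM in this assay, at which 4 of the 4 values shown sit.

The compounds shown leave open which single change, if any, would bring a value inside the limit.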